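Shortening the amine linker on a piperidine kinase inhibitor

The compounds below may be only part of what the source reports. "The series", "measured", "known", "first", "only" and "open" are said of these compounds alone.

Measured compounds:
- compound 1, `NC(c1ccc(Cl)cc1)C1CCN(c2ccnc3[nH]ccc23)CC1`, 12 nM
- compound 2, `NCC1CCN(c2ncnc3[nH]cnc23)CC1`, 290 nM
- compound 3, `NC(c1ccccc1)C1CCN(c2ncnc3[nH]ccc23)CC1`, 246 nM

In an assay on isolated protein for inhibition of RAC-beta serine/threonine-protein kinase (Homo sapiens), read by radiometric assay and filter binding (a lower number here means a stronger inhibitor, a higher number a weaker inhibitor), compound 2 gives the highest number of the three measured compounds; compound 3 is within the scatter of it, while compound 1 sits well below both. Compound 4, `NC1CCN(c2ncnc3[nH]cnc23)CC1`, is not yet measured. It differs from compound 2 in one place: amino in place of aminomethyl on a saturated ring carbon. Going by the values given here, no measured pair shows this change, so its effect cannot be read from the numbers at hand. The expectation is a small step toward a higher number, a 2.1-fold higher number from compound 2 to compound 4 (0.32 log units; beyond the scatter), possibly none beyond the scatter. Compound 4 is therefore estimated at 600 nM, with a range from 150 nM to 3000 nM.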

Compound 4, half-maximal inhibitory concentration: 270 nM
Compound 4: middle estimate off by 2.2-fold (0.35 log units), on the high side, and the stated range covers the measured number.
By their numbers in this assay, from the lowest: compound 1; then compounds 3, 4 and 2 (each within the scatter of the next).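

Amino in place of aminomethyl on this saturated ring carbon gives a 1.1-fold lower number from compound 2 to compound 4 (0.03 log units; within the scatter) in this assay and so leaves the two compounds indistinguishable. Going by these compounds alone, this is the first direct reading of the change: on this core, the amine can sit on the ring carbon itself, without the intervening carbon of aminomethyl, and inhibition still holds. No measured evidence here explains this result.

On these data alone, an aminoethyl chain at this ring carbon, or a hydroxyl in place of the amine, remains open. So does whether the same shortening would read alike on the core of compound 1.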